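The source may hold more compounds than are shown below. What is called first, only, known or untested is meant among the compounds shown, and "the series" means these compounds.

Measured so far:
compound 1, `CCCCCCC#Cc1ccc(S(=O)(=O)Nc2cccc(-c3csc(NC(C)=O)n3)c2)cc1` — 12.8%
compound 2, `CC(=O)Nc1nc(-c2cccc(NS(=O)(=O)c3ccc(C#C[Si](C)(C)C)cc3)c2)cs1` — 4.2%

In a functional assay on A-375 cells (Homo sapiens) for antiproliferative activity, read by trypan blue exclusion, with a stated time of 48 h, tested at 5 uM (a lower number here means a stronger effect, a higher number a weaker effect of the compound at the concentration tested), compound 1 gives 12.8%, the higher of the two numbers shown, while compound 2 gives 4.2%; the step of a number 8.6 percentage points lower from compound 1 to compound 2 (within the scatter) lies within the scatter. Compound 3 `CC(=O)Nc1nc(-c2cccc(NS(=O)(=O)c3ccc(C#CCCc4ccccc4)cc3)c2)cs1` differs from compound 1 by phenyl in place of butyl on a saturated chain carbon, two bonds along the chain from a triple-bonded carbon. Within the data shown here, no measured step touches this place: the one step known, a number 8.6 percentage points lower from compound 1 to compound 2 (within the scatter), changes the group on the triple-bonded carbon itself and stays within the scatter. For compound 3 no step beyond the scatter is therefore expected, a number 0.8 percentage points lower from compound 1 to compound 3 (within the scatter). Compound 3 is estimated at 12%, with a range from 3% to 24%.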

Compound 3, a percentage reported as activity, at one concentration (the size of the read-out at that concentration, not a potency): 4.2%
Compound 3: middle estimate off by 7.8 percentage points, on the high side; the range from low to high includes it.
By their numbers in this assay, from the lowest: compounds 2, 3 and 1 (each within the scatter of the next).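

In this assay phenyl in place of butyl on a saturated chain carbon, two bonds along the chain from a triple-bonded carbon, gives a number 8.6 percentage points lower from compound 1 to compound 3 (within the scatter) and so adds an aromatic ring here without a step beyond the scatter. A ring-bearing group in place of the silicon-bearing group on the triple-bonded carbon gives no change at the digits printed from compound 2 to compound 3 (within the scatter) as well. No evidence is available to explain these results.

As far as these compounds go, how an amine or a carboxylic acid at the end of this chain would read stays open. A single concentration also gives no potency for any of these compounds.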